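The source may report more compounds than this note shows. Statements on the series, on what has been measured and on what is new or still open speak of the compounds shown alone.

Measured compounds in a functional assay on CCRF-CEM cells (Homo sapiens) for antiproliferative activity, read by cell counting, with a stated time of 96 h; a higher number here means a weaker inhibitor, a lower number a stronger inhibitor:

compound 1, `CC(Nc1ccccc1Oc1cccc(F)c1)=C1C(=O)CC(c2ccccc2)CC1=O`: 170 nM
compound 2, `CC(=O)c1ccc(Oc2ccccc2NC(C)=C2C(=O)CC(c3ccccc3)CC2=O)cc1`: 220 nM
compound 3, `CC(Nc1ccccc1Oc1ccccc1)=C1C(=O)CC(c2ccccc2)CC1=O`: 170 nM

Compound 3 stands level with compound 1 at the digits recorded, the two together the lowest numbers of the three; its nearest neighbour is compound 1, and the furthest is compound 2, with a 1.3-fold lower number from compound 2 to compound 3 (0.11 log units; within the scatter) between them, which lies within the scatter. All three share one core and differ only on the phenoxy ring.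

The next compound, compound 4, `CC(Nc1ccccc1Oc1ccc(N)cc1)=C1C(=O)CC(c2ccccc2)CC1=O`, differs from compound 3 by amino in place of hydrogen on an aromatic carbon.

Among the compounds with values here, two measured steps bear on this. The step of a 1.3-fold higher number from compound 1 to compound 2 (0.11 log units; within the scatter) puts a group at the same place, para to a large group, and stays within the scatter. The step of a 1.3-fold lower number from compound 2 to compound 3 (0.11 log units; within the scatter) removes such a group from that place, again within the scatter. The change from hydrogen to fluoro elsewhere on the ring, no change at the digits printed from compound 1 to compound 3 (within the scatter), also shows nothing beyond the scatter. Substitution at this position has so far not moved the number beyond the scatter, and amino is untested; the expectation is therefore a step of about a 1.1-fold higher number from compound 3 to compound 4 (0.05 log units; within the scatter), not beyond the scatter in either direction.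

Compound 4 is estimated at 190 nM, within 90 nM to 400 nM.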

Compound 4, half-maximal inhibitory concentration: 37 nM
Estimate against measurement, compound 4: 5.1-fold (0.71 log units) above; measured number below the stated range.
By their numbers in this assay, from the lowest: compound 4; then compounds 1, 3 and 2 (each within the scatter of the next).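

In this assay, within the data shown here, the 4-aminophenoxy group is the first change on this ring to move the number beyond the scatter, with a 4.6-fold lower number from compound 3 to compound 4 (0.66 log units; beyond the scatter) for amino in place of hydrogen and a 5.9-fold lower number from compound 2 to compound 4 (0.77 log units; beyond the scatter) for amino in place of acetyl at the same place. The place para to a large group therefore responds to substitution, but the result depends on the entering group: compound 2 goes against any general gain from substitution there, since a 1.3-fold lower number from compound 2 to compound 3 (0.11 log units; within the scatter) stays within the scatter. The comparison with the fluorinated compound agrees, with a 4.6-fold lower number from compound 1 to compound 4 (0.66 log units; beyond the scatter) for 4-aminophenyl in place of 3-fluorophenyl, but no measurement shown here accounts for the lower number with amino.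

As far as these compounds go, whether a hydroxyl, a dimethylamino or an acetamido group at this place would give a step of similar size remains open. Also open, from the compounds shown here alone, is whether amino on another carbon of the same ring would match compound 4, and whether the step carries over to any other assay or cell line.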